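The source may hold more compounds than are shown below. What is called first, only, known or untested is meant among the compounds shown, and "the series" means these compounds.

Values measured so far in a functional assay on MCF7 cells (Homo sapiens) for antiproliferative activity, read by MTT assay, with a stated time of 72 h (on this read-out lower numbers stand for stronger inhibition and higher numbers for weaker inhibition), are these:
- compound 1 `CCC/C=C/C(=O)Nc1cccc(Oc2nc(Nc3cccc(OC)c3)nc3c2CSCC3)c1` gives 32000 nM
- compound 2 `C=CC(=O)Nc1cccc(Oc2nc(Nc3cccc(C#N)c3)nc3c2CSCC3)c1` gives 21700 nM
- compound 3 `C/C=C/C(=O)Nc1cccc(Oc2nc(Nc3cccc(C#N)c3)nc3c2CSCC3)c1` gives 21400 nM

Compound 3 stands within the scatter of both other compounds, so the three values cannot be ranked in this assay and form a single band. Compound 4 `CCC/C=C/C(=O)Nc1cccc(Oc2nc(Nc3cccc(C#N)c3)nc3c2CSCC3)c1` follows from compound 3 by one structural change, (ethyl in place of hydrogen on a saturated chain carbon bound to a double-bonded chain carbon), so that the prop-1-en-1-yl on the carbonyl becomes pent-1-en-1-yl.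

Within the data shown here, one measured step bears directly on this change. It is a 1.0-fold lower number from compound 2 to compound 3 (0.01 log units; within the scatter), with prop-1-en-1-yl in place of vinyl on a carbonyl carbon, and it stays within the scatter. Compound 1 already carries pent-1-en-1-yl on the carbonyl, and compound 1 gives 32000 nM, which is within the scatter of the value of compound 3. Neither observation points to a real shift, so no change beyond the scatter is expected in this assay, and no direction can be firmly assigned. The estimated change is small, a 1.2-fold higher number from compound 3 to compound 4 (0.07 log units; within the scatter), and lies within the scatter. Compound 4 is expected to give about 25000 nM, with an estimated range from 13000 nM to 48000 nM in this measurement.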

Compound 4, half-maximal inhibitory concentration: 15300 nM
The estimate for compound 4 lay 1.6-fold (0.21 log units) above the measured number; the measured number falls inside the stated range.
By their numbers in this assay, from the lowest: compounds 4, 3, 2 and 1 (each within the scatter of the next, the first and the last beyond it).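

In this assay ethyl in place of hydrogen on a saturated chain carbon bound to a double-bonded chain carbon gives a 1.4-fold lower number from compound 3 to compound 4 (0.15 log units; within the scatter) and the full exchange of vinyl for pent-1-en-1-yl on the carbonyl gives a 1.4-fold lower number from compound 2 to compound 4 (0.15 log units; within the scatter) so neither step separates these compounds. With the earlier step from vinyl to prop-1-en-1-yl, this means that vinyl, prop-1-en-1-yl and pent-1-en-1-yl on the carbonyl cannot be ranked in this series of nitrile-bearing compounds. Among these compounds, the new compound also provides the first matched pair for the aromatic group, and with pent-1-en-1-yl held constant, cyano in place of methoxy gives a 2.1-fold lower number from compound 1 to compound 4 (0.32 log units; beyond the scatter) which is the only single-place step here beyond the scatter, though only modestly so.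

The compounds shown leave open whether a longer chain on the carbonyl, or an amine at the end of that chain, would move the number beyond the scatter, and whether a chlorine in place of the cyano would keep the gain seen over methoxy. Nothing given here bears on why the cyano and methoxy compounds differ or why the chain changes leave the numbers unresolved.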